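One Methyl Added Twice: Expectation for Compound 4

The source may report more compounds than this note shows. Statements on the series, on what has been measured and on what is new or still open speak of the compounds shown alone.

Measured compounds:
compound 1, `CCOc1ccc(-c2cc(C(=O)O)nn2-c2ccc(Oc3ccccc3)cc2)cc1`, 694 nM
compound 2, `CC(C)Oc1ccc(-c2cc(C(=O)O)nn2-c2ccc(Oc3ccccc3)cc2)cc1`, 932 nM
compound 3, `CCOc1ccc(-c2c(NC(=O)c3ccc(OC(C)C)cc3)c(C(=O)O)nn2-c2ccc(Oc3ccccc3)cc2)cc1`, 28 nM

All three were tested in an assay for displacement of a labelled ligand from Apoptosis regulator Bcl-2 (Homo sapiens), read by fluorescence polarization, with a stated time of 30 min; a higher number here means a weaker inhibitor, a lower number a stronger inhibitor. Compound 1 and compound 2 differ by methyl in place of hydrogen on a saturated chain carbon bound to an oxygen on an aromatic ring and a saturated chain carbon, and this gave a 1.3-fold higher number from compound 1 to compound 2 (0.13 log units; within the scatter). Compound 3 carries a different core; how it differs from compound 1 is not broken down here, but compound 3 stands clearly stronger than both, with compound 1 the nearer of the two.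

Compound 4, `CC(C)Oc1ccc(C(=O)Nc2c(C(=O)O)nn(-c3ccc(Oc4ccccc4)cc3)c2-c2ccc(OC(C)C)cc2)cc1`, has not yet been measured. It differs from compound 3 by methyl in place of hydrogen on a saturated chain carbon bound to an oxygen on an aromatic ring and a saturated chain carbon, the same change as that from compound 1 to compound 2, at a place described in identical words. Since the earlier step on compound 1 stayed within the scatter, the same change on compound 3 is expected to move the number little, and the estimated step is a 1.3-fold higher number from compound 3 to compound 4 (0.11 log units; within the scatter). Compound 4 is therefore expected to give about 36 nM, with a likely range from 15 nM to 90 nM.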

Compound 4, inhibition constant: 140 nM
For compound 4 the middle estimate is 3.9-fold (0.59 log units) below the measured one; the measured number lies above the stated range.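

In this assay, ethoxy to isopropoxy on the core of compound 3 gave a 5.0-fold higher number from compound 3 to compound 4 (0.70 log units; beyond the scatter), so the change that made no clear difference on the earlier core weakened binding here. Set side by side, the two steps do not agree: the same change on two cores in this assay, a 1.3-fold higher number (0.13 log units; within the scatter) from compound 1 to compound 2 and a 5.0-fold higher number (0.70 log units; beyond the scatter) from compound 3 to compound 4, 3.7-fold (0.57 log units) apart, beyond the scatter of two such steps

This shows that, in this series, the size of the step seen on the core of compound 1 cannot simply be carried over to the core of compound 3, though each core is represented by a single pair of compounds, so it does not show why the two steps differ or what the change would do on any other core.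

The compounds shown leave open whether the larger step depends on the amide that compound 3 and compound 4 carry and the earlier pair lacks. They also leave open how a longer chain such as butoxy, or an amine, would behave at the same place on either core.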